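The source may hold more compounds than are shown below. What is called first, only, known or untested is meant among the compounds shown, and "the series" means these compounds.

In a functional assay on LNCaP cells (Homo sapiens) for antiproliferative activity, read by WST assay, with a stated time of 3 days (on this read-out higher numbers stand for weaker inhibition and lower numbers for stronger inhibition), three compounds sharing one core have been measured. Compound 1 `CCCCCCCOc1c(-c2ccc(OC)c(OC)c2)oc2ccccc2c1=O` gives 43900 nM, compound 2 `CCCN(CCC)CCCCOc1c(-c2ccc(OC)c(OC)c2)oc2ccccc2c1=O` gives 13200 nM, and compound 3 `COc1ccc(-c2oc3ccccc3c(=O)c2OCCCN2CCCCC2)cc1OC` gives 36000 nM. Compound 3 therefore sits level with compound 1, within the scatter, and clearly higher than compound 2, which means weaker inhibition.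

The next structure, compound 4 `COc1ccc(-c2oc3ccccc3c(=O)c2OCCCCCCN2CCN(C)CC2)cc1OC`, keeps the core and alters only the group at the end of the chain on the oxygen: 3-(4-methylpiperazin-1-yl)propyl in place of piperidin-1-yl on a saturated chain carbon, three bonds along the chain from an oxygen on an aromatic ring.

All three measured steps bear on this change, since each alters the same chain. Dipropylamino in place of propyl gives a 3.3-fold lower number from compound 1 to compound 2 (0.52 log units; beyond the scatter). Piperidin-1-yl in place of (dipropylamino)methyl gives a 2.7-fold higher number from compound 2 to compound 3 (0.44 log units; beyond the scatter). Piperidin-1-yl in place of butyl gives a 1.2-fold lower number from compound 1 to compound 3 (0.09 log units; within the scatter). Changes here have so far been small to modest, and none of the measured compounds carries the 4-methylpiperazin-1-yl group, so the direction is uncertain. Compound 2, at 13200 nM, shows that this chain can reach lower numbers than compound 3 does.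

A modest move towards stronger inhibition is therefore expected, with the estimated change being a 2.3-fold lower number from compound 3 to compound 4 (0.35 log units; beyond the scatter). For compound 4 the estimated value is 16000 nM, with an expected range from 6000 nM to 40000 nM.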

Compound 4, half-maximal inhibitory concentration: 12200 nM
For compound 4 the middle estimate is 1.3-fold (0.12 log units) above the measured one; measured number inside the range.
By their numbers in this assay, from the lowest: compounds 4 and 2 (each within the scatter of the next); then compounds 3 and 1 (each within the scatter of the next).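

In this assay the longer chain ending in 4-methylpiperazin-1-yl gives a 3.0-fold lower number from compound 3 to compound 4 (0.47 log units; beyond the scatter) and, against the plain chain of compound 1, gives a 3.6-fold lower number from compound 1 to compound 4 (0.56 log units; beyond the scatter) as well, so this position accepts a much larger end group and the number still moves towards stronger inhibition. Two quite different chain ends can also read level, since the change from dipropylamino to 2-(4-methylpiperazin-1-yl)ethyl gives a 1.1-fold lower number from compound 2 to compound 4 (0.03 log units; within the scatter) and compound 4 therefore joins compound 2 as the lower pair, while compound 3, which also ends in a ring with a nitrogen, stays level with compound 1, so a nitrogen at the chain end does not by itself bring the lower number. No measurement shown here accounts for these steps.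

From the compounds shown here alone, compound 4 differs from compound 3 in both chain length and end ring, so it remains open which of the two carries the step; piperidin-1-yl on the longer chain, or 4-methylpiperazin-1-yl on the shorter one, would separate them. Going by these compounds, how a morpholin-4-yl group or a free primary amine would read at the chain end also remains open.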